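Swapping the ring-nitrogen substituent of a benzamide dithiocarbamate

The source may report more compounds than this note shows. Statements on the series, on what has been measured and on what is new or still open speak of the compounds shown alone.

Two benzamide dithiocarbamates have been tested in a functional assay on MGC-803 cells (Homo sapiens) for antiproliferative activity, read by CCK-8 assay, with a stated time of 72 h, tested at 8 uM; on this read-out lower numbers stand for a weaker effect and higher numbers for a stronger effect at the one concentration tested. Compound 1, `COc1ccc(N2CCN(C(=S)SCc3ccc(C(=O)Nc4ccccc4N)cc3)CC2)cc1`, gives 22.9% in this assay. Compound 2, `CN(C(=S)SCc1ccc(C(=O)Nc2ccccc2N)cc1)c1cccnc1`, gives 82.5% in this assay. Among these two numbers compound 1 stands lowest, and the gap to compound 2 lies beyond the usual scatter of such measurements, so compound 2 shows the clearly stronger effect here.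

Compound 3, `Nc1ccccc1NC(=O)c1ccc(CSC(=S)N2CCN(Cc3cccnc3)CC2)cc1`, has not yet been measured in this assay. It differs from compound 1 in one place: (pyridin-3-yl)methyl in place of 4-methoxyphenyl on an amine nitrogen in a ring. Since compound 1 and compound 3 share the rest of their structure, the whole difference in the read-out can be tied to this one exchange.

Within the data shown here, no measured pair in this set makes exactly this exchange, so its effect has to be guessed. Compound 2, the stronger of the two measured compounds, carries a pyridine-type ring, which compound 3 also gains; on that slender basis a rise in the read-out is expected for compound 3, of the size a number 22.1 percentage points higher from compound 1 to compound 3 (beyond the scatter). Compound 3 is therefore estimated to give 45% in this assay, within a range from 20% to 75%.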

Compound 3, a percentage reported as inhibition, at one concentration (the size of the read-out at that concentration, not a potency): 64.6%
For compound 3 the middle estimate is 19.6 percentage points below the measured one, within the range that was stated.
By their numbers in this assay, from the lowest: compound 1; then compound 3; then compound 2.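

In this assay, the substituent on the ring nitrogen of the six-membered non-aromatic ring proves to matter a great deal: with the rest of the structure held constant, putting (pyridin-3-yl)methyl in place of 4-methoxyphenyl gives a number 41.7 percentage points higher from compound 1 to compound 3 (beyond the scatter). The earlier compounds shown here could not show this, as they differ from each other in more than one place, whereas this step ties a large change in the read-out to this single position. The two groups match in their counts of hydrogen-bond donors, hydrogen-bond acceptors and net charge, and nothing measured here accounts for the size of the step.

The exchange replaces a carbon-only aromatic ring with a pyridine ring and also alters how that ring is attached, so a benzyl group or a directly attached pyridin-3-yl group on the same nitrogen would be needed to separate these two changes. Going by these compounds, how far the effect extends to other kinds of substituent, such as a longer chain like 2-(pyridin-3-yl)ethyl or a chain ending in an amine, also remains open.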